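Stretching one hydroxy arm of compound 2

A few compounds are considered here, and "the series" means these few. Any claim that something is new, unique, unknown or untested is made for them only; others in the source may bear on it.

Compound 1, `CCCCCCCCc1ccc(CCC(N)CO)cc1`, carries an amine with one hydroxymethyl arm. In a functional assay on the whole organism (spleen, spleen) with Rattus norvegicus as the target (on this read-out lower numbers stand for an effect already at smaller amounts and higher numbers for an effect only at larger amounts of compound), compound 1 gives only > 10 mg/kg, which is a limit of the assay rather than a number. Compound 2, `CCCCCCCCc1ccc(CCC(N)(CO)CCO)cc1`, adds a 2-hydroxyethyl arm on the same carbon, and in this assay compound 2 gives 0.009 mg/kg, the only number shown here. Within the data shown here, the step of an at least 1100-fold lower number from compound 1 to compound 2 (3.04 log units; beyond the scatter) is the only measured step, and it is anchored at the limit of > 10 mg/kg in this assay, at which 1 of the 2 values shown sits, on the side of compound 1.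

Compound 3, `CCCCCCCCc1ccc(CCC(N)(CCO)CCO)cc1`, differs from compound 2 by hydroxymethyl in place of hydroxy on a saturated chain carbon, two bonds along the chain from an amine nitrogen, so that both arms on that carbon become 2-hydroxyethyl. The measured step concerns adding an arm, not lengthening one, so it bears on the change only loosely. Since the enlarged arm of compound 2 already drove the number down in the step of an at least 1100-fold lower number from compound 1 to compound 2 (3.04 log units; beyond the scatter), a small to moderate shift, more likely towards a higher number, is expected from compound 2 to compound 3, a 3.3-fold higher number from compound 2 to compound 3 (0.52 log units; beyond the scatter). Compound 3 is therefore expected to give about 0.03 mg/kg in this assay, between 0.005 mg/kg and 0.3 mg/kg.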

Compound 3, dose for 50% inhibition: > 10 mg/kg
Compound 3 was reported as a limit; the forecaster's own chance of this, stated with the estimate: 10%; middle value at least 330-fold (2.52 log units) away from the limit.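

In this assay, the change on a saturated chain carbon, two bonds along the chain from an amine nitrogen, proves far from minor: hydroxymethyl in place of hydroxy gives an at least 1100-fold higher number from compound 2 to compound 3 (3.04 log units; beyond the scatter), so the effect seen with the earlier arrangement is lost again. Compound 3 also carries a second arm on that carbon, which shows that a second arm alone does not suffice; among the three compounds shown, a measurable number appears only with one hydroxymethyl arm paired with one 2-hydroxyethyl arm. The results for compound 1 and compound 3 are both limits of the assay and not numbers, so the step between them cannot be read, and neither compound can be ranked against the other: the limit of > 10 mg/kg in this assay, at which 2 of the 3 values shown sit.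

The compounds shown leave open whether two hydroxymethyl arms on that carbon, or a 3-hydroxypropyl arm paired with hydroxymethyl, would give a measurable number. They also leave open whether an amine or a carboxylic acid could take the place of the terminal hydroxy on the 2-hydroxyethyl arm, and whether a longer chain on the core would change the picture.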